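The source may hold more compounds than are shown below. What is called first, only, known or untested is meant among the compounds shown, and "the series" means these compounds.

Three compounds of the shared core have been run in a functional assay on SNB-19 cells (Homo sapiens) for inhibition, read by sulforhodamine B assay, with a stated time of 48 h; a lower number here means a stronger inhibitor of growth, a higher number a weaker inhibitor of growth. Compound 1 `Nc1cc(N)c2nc(-c3ccccc3)c(NCc3ccc(Cl)c(Cl)c3)nc2c1` gives 51300 nM. Compound 2 `Nc1cc(N)c2nc(-c3ccccc3)c(NCc3ccc(F)cc3)nc2c1` gives 20000 nM, the lowest of the two numbers, and the step of a 2.6-fold lower number from compound 1 to compound 2 (0.41 log units; beyond the scatter) lies beyond the scatter. Compound 3 `COc1ccc(CNc2nc3cc(N)cc(N)c3nc2-c2ccccc2)cc1` is reported only as a limit, < 100000 nM. The limit of < 100000 nM in this assay, at which 1 of the 3 values shown sits, therefore holds one of the three values. Compound 4 `Nc1cc(N)c2nc(-c3ccccc3)c(Oc3ccc(F)cc3)nc2c1` carries 4-fluorophenoxy in place of (4-fluorobenzyl)amino on an aromatic carbon. For the measured compounds named here, no measured step touches that part: the steps of a 2.6-fold lower number from compound 1 to compound 2 (0.41 log units; beyond the scatter), a step that the limit leaves unreadable from compound 1 to compound 3 and a step that the limit leaves unreadable from compound 2 to compound 3 vary only the substituent on the pendant ring, so they give no direction for compound 4. The step from compound 2 to compound 4 is estimated as a 1.5-fold higher number from compound 2 to compound 4 (0.18 log units; within the scatter). Compound 4 is expected near 30000 nM, between 8000 nM and 120000 nM.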

Compound 4, concentration for total growth inhibition: 33900 nM
For compound 4 the middle estimate is 1.1-fold (0.05 log units) below the measured one; the range from low to high includes it.
By their numbers in this assay, from the lowest: compounds 2, 4 and 1 (each within the scatter of the next, the first and the last beyond it).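

In this assay, for the compounds shown here, this is the first change to the link at this aromatic carbon rather than to the substituent on the pendant ring: 4-fluorophenoxy in place of (4-fluorobenzyl)amino gives a 1.7-fold higher number from compound 2 to compound 4 (0.23 log units; within the scatter), so the two linked groups are not separated here. The 4-fluorophenyl part is held constant across this step, which isolates the change to the linker. Nothing shown gives a cause for this step.

Still open, from the compounds shown here alone, is whether a sulfur link or a longer chain at this carbon would separate from compound 2. Also open, going by these compounds, is how an amine or a carboxylic acid on the pendant ring would read with the oxygen link.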